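The source may report more compounds than this note shows. Statements on the series, on what has been measured and on what is new or still open speak of the compounds shown alone.

Working notes on the chalcone set. Compound 1 `COc1cc(O)c(CC=C(C)C)c(O)c1C(=O)/C=C/c1ccc([N+](=O)[O-])cc1` and compound 2 `COc1cc(O)c(CC=C(C)C)c(O)c1C(=O)/C=C/c1ccc(C(F)(F)F)cc1` share one core; compound 3 `COc1cc(OC)c(C(=O)/C=C/c2ccc([N+](=O)[O-])cc2)c(OC)c1` and compound 4 `COc1cc(OC)c(C(=O)/C=C/c2ccc(C(F)(F)F)cc2)c(OC)c1` share another. How the two cores differ is not broken down here.

In a functional assay on HeLa cells (Homo sapiens) for inhibition, read by MTT assay, with a stated time of 72 h (on this read-out lower numbers stand for stronger inhibition and higher numbers for weaker inhibition), compound 1 gives 29700 nM, and compound 2 gives 6800 nM. The change between them is trifluoromethyl in place of nitro on an aromatic carbon; it produced a 4.4-fold lower number from compound 1 to compound 2 (0.64 log units; beyond the scatter). Compound 3 gives 8000 nM in this assay, which sits within the scatter of compound 2 and beyond it relative to compound 1.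

The change from compound 3 to compound 4 is trifluoromethyl in place of nitro on an aromatic carbon, the same change as from compound 1 to compound 2, made on the second core. It occurs twice among these compounds, with only one measured instance. Going by the values given here, the expectation for compound 4 rests on the single step of a 4.4-fold lower number from compound 1 to compound 2 (0.64 log units; beyond the scatter) seen on the first core, tempered in that a change is not guaranteed to carry over unchanged between cores. Compound 4 is therefore expected to move by about a 3.6-fold lower number from compound 3 to compound 4 (0.56 log units; beyond the scatter) from compound 3 in this assay. The estimate for compound 4 is 2200 nM, with a plausible range from 700 nM to 7000 nM.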

Compound 4, half-maximal inhibitory concentration: 5100 nM
For compound 4 the middle estimate is 2.3-fold (0.37 log units) below the measured one; low and high end bracket the measured number.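

The same exchange does not carry over at the same size between the two cores. On the core of compound 3 in this assay, trifluoromethyl in place of nitro gives a 1.6-fold lower number from compound 3 to compound 4 (0.20 log units; within the scatter), against a clearly larger step on the core of compound 1: the same change on two cores in this assay, a 4.4-fold lower number (0.64 log units; beyond the scatter) from compound 1 to compound 2 and a 1.6-fold lower number (0.20 log units; within the scatter) from compound 3 to compound 4, 2.8-fold (0.44 log units) apart, beyond the scatter of two such steps.
The exchange therefore separates the two compounds beyond the scatter on the first core only, and a step read on one core is a poor guide to its size on the other. With just two pairs, these data do not show which structural difference between the cores goes with the gap, nor how a further core would respond.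

Open, on these data alone, is whether other groups on that aromatic carbon, such as an amine, a carboxylic acid or a nitrile, would also give steps that differ between the two cores. Also open, as far as these compounds go, is whether any such group would separate from nitro on the core of compound 3 by more than the scatter.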